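Indazole N-methylation in a weak UFO kinase series

This account rests on a few compounds, and the source may have more. Where it says the series, first, only, none or still open, it means among the compounds named here.

Measured so far:
compound 1 `Nc1ccc(Br)c2ccncc12`: 57000 nM
compound 2 `Cn1cc(-c2n[nH]c3cc(N)ccc23)cn1`: 28800 nM

Two compounds have numbers. In an assay on isolated protein for inhibition of tyrosine-protein kinase receptor UFO (Homo sapiens), with a stated time of 1.5 h (a lower number here means a stronger inhibitor, a higher number a weaker inhibitor), compound 1 gives 57000 nM, and in this assay compound 2 gives 28800 nM. Compound 2 has the lowest of the two numbers; the nearest is compound 1, whose number is higher by an amount that lies within the scatter, so the two cannot be ordered against each other. Among the measured compounds shown here, no pair of measured compounds differs in one place, so no step size is known from the data.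

Compound 3 `Cn1cc(-c2nn(C)c3cc(N)ccc23)cn1` differs from compound 2 by methyl in place of hydrogen on an aromatic nitrogen. For the measured compounds named here, with no measured step to lean on, the expectation rests on compound 2 alone, whose number in this assay is 28800 nM, already a weak inhibition. A modest weakening is expected, possibly not beyond the scatter, with a real chance that only a limit is returned. The expected step of a 2.1-fold higher number from compound 2 to compound 3 (0.32 log units; beyond the scatter) is an estimate only. Compound 3 is expected to give 60000 nM in this assay, within 15000 nM to 250000 nM.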

Compound 3, half-maximal inhibitory concentration: > 384000 nM
Compound 3: no number, only a limit; the forecaster's own chance of this, stated with the estimate: 35%; middle value at least 6.4-fold (0.80 log units) from the limit.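

Among the compounds shown here, on the aromatic nitrogen of compound 2, methyl in place of hydrogen gives the first step that can be sized: in this assay it is an at least 13-fold higher number from compound 2 to compound 3 (1.12 log units; beyond the scatter), large and beyond the scatter, whereas the earlier compounds offered no pair differing in one place. Compound 3 gives > 384000 nM, which is a limit and not a number, so the step has a floor but no measured size. This is the only compound shown that carries no number, and its result marks this nitrogen as a place where the addition of a single carbon is not neutral in this series: the limit of > 384000 nM in this assay, at which 1 of the 3 values shown sits.

Still open, going by these compounds, is whether any other group on this aromatic nitrogen, such as ethyl or a longer chain ending in a hydroxyl, would also end at a limit, or whether a number would return. On these data alone, the reading also rests on one pair, with compound 2 as a weak starting point at 28800 nM, so whether the same change costs as much on a stronger member of the series stays unknown.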